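The source may report more compounds than this note shows. Statements on the series, on what has been measured and on what is new or still open speak of the compounds shown alone.

Working notes on the series.

Compound 1 `C[C@@H](O)[C@H](NC(=O)CN(c1nc(Cl)nc2[nH]cnc12)C1CC1)C(=O)O` carries the acid and the 1-hydroxyethyl side chain on the chlorinated core. For the measured compounds named here, in a functional assay on the whole organism (Tail, strain ICR) with Mus musculus as the target, in the tail flick test, with a stated time of 60 min, at a dose of 25 umol/kg by the oral route (a lower number here means a weaker effect, a higher number a stronger effect of the compound at the dose given), compound 1 gives 30.1%, the lowest of the two numbers measured so far. Compound 2 `C[C@H](NC(=O)CN(c1ncnc2c1ncn2C1CCCCO1)C1CC1)C(=O)OCc1ccccc1` differs from compound 1 in several places at once; in this assay compound 2 gives 53%. Going by the values given here, that reading is higher than the one of compound 1 by an amount beyond the scatter; as the two structures differ in more than one place, nothing more is read from that pair.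

Compound 3 `CC(C)[C@H](NC(=O)CN(c1nc(Cl)nc2[nH]cnc12)C1CC1)C(=O)O` is the next member. It differs from compound 1 as follows: isopropyl in place of 1-hydroxyethyl on a saturated chain carbon bound to an amide-type nitrogen and a carbonyl carbon. Among the compounds with values here, no measured pair shows this single change, so no size of step can be taken from the data. The expectation is a step from compound 1 to compound 3 of a number 1.9 percentage points higher from compound 1 to compound 3 (within the scatter), that is, none beyond the scatter. For compound 3 the estimated reading in this assay is 32%, within a range from 15% to 50%.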

Compound 3, a percentage reported as activity, at one dose (the size of the read-out at that dose, not a potency): 38.8%
Estimate against measurement, compound 3: 6.8 percentage points below, and the stated range covers the measured number.
By their numbers in this assay, from the lowest: compounds 1 and 3 (each within the scatter of the next); then compound 2.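

For the compounds shown here, this is the first comparison that differs in one place only. On a saturated chain carbon bound to an amide-type nitrogen and a carbonyl carbon, isopropyl in place of 1-hydroxyethyl gives in this assay a number 8.7 percentage points higher from compound 1 to compound 3 (within the scatter). The position therefore takes a group with 0 hydrogen-bond donors and 0 hydrogen-bond acceptors in place of one with 1 of each, and loses the defined stereocentre of 1-hydroxyethyl, without a reading that can be told apart from the one before; with the acid and the core held, the effect at this dose does not hang on the hydroxyl of that side chain, and nothing at hand bears on why the two readings stay together.

Both groups have 3 heavy atoms and no ring, so the compounds shown leave open what a longer chain such as n-butyl, a benzyl group, an amine or a carboxylic acid would do on the same carbon. They also leave open whether the same exchange behaves alike on the benzyl ester of compound 2, which differs from compound 1 in several places at once.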